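Shortening the amine side chain of compound 2

A few compounds are considered here, and "the series" means these few. Any claim that something is new, unique, unknown or untested is made for them only; others in the source may bear on it.

Compound 2 `CC(C)C[C@@H](N)CN(C(=O)[C@@H]1C[C@H]1c1ccccc1)c1ccc(-c2ccccc2)cc1` gives 1.8 nM in a functional assay for agonist activity at G protein-coupled receptor 88 (Homo sapiens), read by HTRF and cAMP accumulation (on this read-out lower numbers stand for an effect already at smaller amounts and higher numbers for an effect only at larger amounts of compound), which is the top of the two numbers shown; compound 1 `CC(C)C[C@H](N)CN(C(=O)C(C)Cc1ccccc1)c1ccc(-c2ccccc2)cc1` gives 1.2 nM, a gap within the scatter, so nothing separates the two. Compound 3 `CC(C)[C@H](N)CN(C(=O)[C@@H]1C[C@H]1c1ccccc1)c1ccc(-c2ccccc2)cc1` is compound 2 with one change: 1-amino-2-methylpropyl in place of 1-amino-3-methylbutyl on a saturated chain carbon bound to an amide-type nitrogen. Among the compounds with values here, no measured pair shows this change, so its effect is unknown from the data. A modest step, toward a higher number or none beyond the scatter, is expected, a 1.9-fold higher number from compound 2 to compound 3 (0.29 log units; within the scatter) being the estimated step. Compound 3 is expected to give 3.5 nM, within 1 nM to 12 nM.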

Compound 3, half-maximal effective concentration: 1.1 nM
Estimate against measurement, compound 3: 3.2-fold (0.50 log units) above, and the stated range covers the measured number.
By their numbers in this assay, from the lowest: compounds 3, 1 and 2 (each within the scatter of the next).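

This is the first step shown at this position: on a saturated chain carbon bound to an amide-type nitrogen, 1-amino-2-methylpropyl in place of 1-amino-3-methylbutyl gives a 1.6-fold lower number from compound 2 to compound 3 (0.21 log units; within the scatter) in this assay. The shorter branched chain is therefore accommodated here with no measurable change in this read-out. No measurement available here explains this result.

As far as these compounds go, it remains open whether a still shorter 1-aminoethyl group or a ring-bearing 1-amino-1-cyclohexylmethyl group would give a similar number. From the compounds shown here alone, it is equally open whether a hydroxyl group could stand in place of the amine.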